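A few compounds are considered here, and "the series" means these few. Any claim that something is new, unique, unknown or untested is made for them only; others in the source may bear on it.

The compounds in this set share one core, seen in compound 1 `COc1ncc(-c2ccc3c(c2)N(c2ccc(C)cc2)C(=O)CO3)cc1NS(=O)(=O)c1ccc(F)cc1`. In a functional assay on HCT-116 cells (Homo sapiens) for antiproliferative activity, read by MTT assay, with a stated time of 72 h (a lower number here means a stronger inhibitor, a higher number a weaker inhibitor), compound 1 gives 22700 nM. Compound 3 `O=C1COc2ccc(-c3cnc4ccccc4c3)cc2N1c1ccc(Cl)cc1` gives 36100 nM in this assay, a number that sits within the usual scatter of that of compound 1, so the two cannot be told apart. Compound 2 `O=C1COc2ccc(-c3cccc(NS(=O)(=O)c4ccc(F)cc4)c3)cc2N1c1ccccc1` reaches only a limit in this assay, > 40000 nM, and no number is known for it; the set thus contains (the limit of > 40000 nM in this assay, at which 1 of the 3 values shown sits). Among the two numbers actually measured, compound 1 holds the lower one.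

Compound 4 `COc1ncc(-c2ccc3c(c2)N(C2CCCCC2)C(=O)CO3)cc1NS(=O)(=O)c1ccc(F)cc1` has not yet been measured in this assay. It differs from compound 1 in a single place: cyclohexyl in place of 4-methylphenyl on an amide-type nitrogen in a ring. For the measured compounds named here, no measured pair in this set carries such a change, so the data themselves give neither a size nor a direction for the step. Without such a pair, the step from compound 1 to compound 4 is expected to be small, a 1.3-fold higher number from compound 1 to compound 4 (0.12 log units; within the scatter), lying within the scatter or only a little beyond it. Compound 4 is therefore expected to give about 30000 nM in this assay, with a range from 10000 nM to 90000 nM.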

Compound 4, half-maximal inhibitory concentration: > 40000 nM
Compound 4 was reported as a limit; the forecaster's own chance of this, stated with the estimate: 35%; middle value at least 1.3-fold (0.12 log units) from the limit.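

In this assay compound 4 reaches only a limit (> 40000 nM) and not a number. For the compounds shown here, the change of cyclohexyl in place of 4-methylphenyl on the amide-type nitrogen in a ring can therefore be given only as a floor (an at least 1.7-fold higher number from compound 1 to compound 4 (0.24 log units; that floor lies within the scatter)), which is the first measured step at this position: it shows no gain in potency from the non-aromatic ring, but since that floor lies within the scatter, it does not establish a real loss either. The result also adds to the compounds that cannot be ranked against each other, and the top of the measurable range now holds as many compounds as carry numbers: (the limit of > 40000 nM in this assay, at which 2 of the 4 values shown sit).

On these data alone, how far the true value lies past the limit remains unknown, so the full size of the step stays open, and a single change cannot show whether an aromatic ring on this nitrogen matters in general. Also open, as far as these compounds go, is whether a different group at this place, such as a short methyl or a longer chain ending in an amine, would give a lower number than compound 1 does (22700 nM).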